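This account rests on a few compounds, and the source may have more. Where it says the series, first, only, none or still open, it means among the compounds named here.

Measured so far in a functional assay on HT-29 cells (Homo sapiens) for antiproliferative activity, read by sulforhodamine B assay, with a stated time of 72 h; on this read-out higher numbers stand for weaker inhibition and lower numbers for stronger inhibition:
compound 1, `CCCCCCCCc1ccc(CCC(CO)(CO)NC(=O)CCC)c2ccccc12`, gives 26400 nM;
compound 2, `CCCCCCCCc1ccc(CCC(CO)(CO)NC(=O)CCCCC)c2ccccc12`, gives 20300 nM;
compound 3, `CCCCCCCOc1ccc(CCC(CO)(CO)NC(=O)CCCCC)c2ccccc12`, gives 21900 nM.

All three numbers lie within the usual scatter of one another, so no order among them can be read off. Compound 4, `CCCCCCCOc1ccc(CCC(CO)(CO)NC(=O)CCCCCCC)c2ccccc12`, has not yet been measured in this assay. It differs from compound 3 by ethyl in place of hydrogen on a saturated chain carbon, five bonds along the chain from a carbonyl carbon. The same kind of change, (ethyl in place of hydrogen on a saturated chain carbon, three bonds along the chain from a carbonyl carbon), has already been made once among the measured compounds, where it gave a 1.3-fold lower number from compound 1 to compound 2 (0.11 log units; within the scatter). The two places are not identical: in the earlier pair the ethyl enters three bonds along the chain from a carbonyl carbon, in the new pair five bonds along the chain from a carbonyl carbon. The difference between the core of compound 1 and the core of compound 3 is not broken down here.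

Within the data shown here, for compound 4 a step of about a 1.4-fold lower number from compound 3 to compound 4 (0.14 log units; within the scatter) is expected in this assay, resting on the single earlier step of a 1.3-fold lower number from compound 1 to compound 2 (0.11 log units; within the scatter), which was small. The estimate for compound 4 is 16000 nM, with a likely range from 7000 nM to 40000 nM.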

Compound 4, half-maximal inhibitory concentration: 18800 nM
Compound 4: the middle estimate sits 1.2-fold (0.07 log units) below what was measured; the range from low to high includes it.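

Swapping hydrogen for ethyl on a saturated chain carbon, five bonds along the chain from a carbonyl carbon, gives a 1.2-fold lower number from compound 3 to compound 4 (0.07 log units; within the scatter) in this assay. Set beside the same kind of change on the other core, three bonds along the chain from a carbonyl carbon, the two steps do not differ: the same change on two cores in this assay, a 1.3-fold lower number (0.11 log units; within the scatter) from compound 1 to compound 2 and a 1.2-fold lower number (0.07 log units; within the scatter) from compound 3 to compound 4, 1.1-fold (0.05 log units) apart, within the scatter of two such steps. This shows that the change does about the same small thing on both cores, but each step is within the scatter, so the agreement is one of two steps that are hardly distinguishable from no effect, and it does not show that a step of real size would carry from one core to the other.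

The compounds shown leave open whether a much longer chain on the amide, or an amine or a carboxylic acid at the end of that chain, would give a step beyond the scatter. They also leave open what a short chain in place of the octyl or heptyloxy group would do.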